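The compounds below may be only part of what the source reports. "The series", "measured", "known", "first", "only" and "open" are said of these compounds alone.

Compound 1 `COc1ccc(/C=N/NC(=O)Nc2cc3c(Nc4ccc(F)c(Cl)c4)ncnc3cc2O[C@H]2CCOC2)cc1`: 28800 nM
Compound 2 `COc1cc2ncnc(Nc3ccc(F)c(Cl)c3)c2cc1NC(=O)N/N=C/c1ccc(F)cc1Cl`: 29200 nM

Of the compounds shown here, two have been measured so far in a functional assay on HepG2 cells (Homo sapiens) for cytotoxicity, read by MTT assay, with a stated time of 72 h; a higher number here means a weaker inhibitor, a lower number a stronger inhibitor. Compound 2, at 29200 nM, stands level with compound 1 at 28800 nM, as the two values lie within the scatter of each other.

The next compound to be tested is compound 3 `COc1ccc(/C=N/NC(=O)Nc2cc3c(Nc4ccc(F)c(Cl)c4)ncnc3cc2OC)cc1`. It differs from compound 2 by 4-methoxyphenyl in place of 2-chloro-4-fluorophenyl on a carbon with a double bond to nitrogen, with 4-methoxyphenyl in place of 2-chloro-4-fluorophenyl on a carbon with a double bond to nitrogen. Among the measured compounds shown here, no measured pair of compounds differs in one place only, so the data do not show what a single change does in this assay. With only these two values to go on, no shift beyond the scatter is expected. The expected result is a 1.2-fold lower number from compound 2 to compound 3 (0.07 log units; within the scatter). For compound 3 the estimated value is 25000 nM, with an expected range of 10000 nM to 55000 nM.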

Compound 3, half-maximal inhibitory concentration: 21300 nM
The estimate for compound 3 lay 1.2-fold (0.07 log units) above the measured number; the range from low to high includes it.
By their numbers in this assay, from the lowest: compounds 3, 1 and 2 (each within the scatter of the next).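

Among the compounds shown here, compound 3 provides the first comparisons in this assay between compounds that differ in one place only. On the carbon with a double bond to nitrogen, 4-methoxyphenyl in place of 2-chloro-4-fluorophenyl gives a 1.4-fold lower number from compound 2 to compound 3 (0.14 log units; within the scatter) and, on the oxygen on an aromatic ring, methyl in place of oxolan-3-yl gives a 1.4-fold lower number from compound 1 to compound 3 (0.13 log units; within the scatter) so neither exchange separates its two groups in this assay. No supporting measurement is available that bears on this result.

The compounds shown leave open whether either place responds to groups of another kind, such as a phenyl carrying an amine or a carboxylic acid on the carbon with a double bond to nitrogen. From the compounds shown here alone, a longer chain on the oxygen on an aromatic ring also remains untested among them.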